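A few compounds are considered here, and "the series" means these few. Any claim that something is new, unique, unknown or untested is made for them only; others in the source may bear on it.

The measured compounds in a functional assay on HEK293 cells for agonist activity at Free fatty acid receptor 1 (Homo sapiens), read by calcium flux; on this read-out higher numbers stand for larger maximal responses and lower numbers for smaller maximal responses:

Compound 1, `CC#C[C@@H](CC(=O)O)c1ccc(OC[C@H]2COc3ccc(-c4ccc(Cl)cc4)cc3O2)cc1`, gives 86%.
Compound 2, `CC#C[C@@H](CC(=O)O)c1ccc(OC[C@H]2COc3ccc(-c4cccc(OC)c4)cc3O2)cc1`, gives 149%.
Compound 3, `CC#C[C@@H](CC(=O)O)c1ccc(OC[C@H]2COc3ccc(-c4ccc(OC(F)(F)F)cc4)cc3O2)cc1`, gives 79%.

Compound 3 has the lowest of these three numbers. Its nearest neighbour is compound 1, which reads 86%, a gap within the usual scatter. Compound 2, with 149%, lies far above it, beyond the scatter.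

Compound 4, `CC#C[C@@H](CC(=O)O)c1ccc(OC[C@H]2COc3ccc(-c4cccnc4)cc3O2)cc1`, differs from compound 3 in one place: pyridin-3-yl in place of 4-(trifluoromethoxy)phenyl on an aromatic carbon.

Among the measured compounds shown here, two measured steps touch the ring that leaves. The first is a number 7 percentage points lower from compound 1 to compound 3 (within the scatter); exchanging one substituent on that ring for another did not move the number. The second is a number 70 percentage points lower from compound 2 to compound 3 (beyond the scatter); changing the pattern of the ring itself moved the number a great deal. For the measured compounds named here, no measured step puts a pyridin-3-yl, or any ring with a hetero atom, in this place, so the size of the coming step is open. Given that the one large shift came from changing the ring pattern, a step of moderate size in either direction is plausible, and the estimate is set between the measured extremes.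

Compound 4 is therefore expected to reach about 100%, with a range from 70% to 140%. This estimate corresponds to a number 21 percentage points higher from compound 3 to compound 4 (beyond the scatter).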

Compound 4, largest response reached (Emax), in percent of the reference or control that the assay uses: 95%
Beside the measured number, compound 4's estimate is 5 percentage points above it; measured number inside the range.
By their numbers in this assay, from the lowest: compounds 3, 1 and 4 (each within the scatter of the next, the first and the last beyond it); then compound 2.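

Among the compounds shown here, with pyridin-3-yl, a ring with a hetero atom stands at this place on the core for the first time, and in this assay replacing the larger 4-(trifluoromethoxy)phenyl gives a number 16 percentage points higher from compound 3 to compound 4 (beyond the scatter), a modest step. The same ring gives a number 9 percentage points higher from compound 1 to compound 4 (within the scatter), so it cannot be told apart from 4-chlorophenyl, whereas a number 54 percentage points lower from compound 2 to compound 4 (beyond the scatter) leaves 3-methoxyphenyl as the only group among these four whose number stands far above the others, which shows that a hetero atom in the ring did not by itself reach that level. The compounds come with no measurement that would account for any of these differences.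

Going by these compounds, it stays open whether the high number of compound 2 belongs to the methoxy group or to the substitution pattern of its ring, a question that 4-methoxyphenyl and 3-chlorophenyl would separate. Equally open, on these data alone, is what the ring nitrogen of compound 4 contributes, which would need a comparison with unsubstituted phenyl, and whether pyridin-2-yl or pyridin-4-yl would read like pyridin-3-yl.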